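Chloro for Bromo on a Shared Core: Tolerance Outlook

The compounds below may be only part of what the source reports. "The series", "measured", "known", "first", "only" and "open" are said of these compounds alone.

Measured compounds:
Compound 1 `Brc1ccc(Cc2nnc(Cn3nnc4ccccc43)o2)cc1`: > 100000 nM
Compound 2 `Brc1cccc(-c2nnc(Cn3nnc4ccccc43)o2)c1`: > 100000 nM

In an ADME assay on cells (Macrophage, Homo sapiens) for inhibition (a higher number here means that more compound is tolerated, a lower number that less compound is tolerated), compound 1 gives only a limit, > 100000 nM. Compound 2 likewise gives only a limit, > 100000 nM. Compound 2 therefore stands at the limit of > 100000 nM in this assay, at which 2 of the 2 values shown sit, with no number to separate it from compound 1. Compound 3 `Clc1cccc(-c2nnc(Cn3nnc4ccccc43)o2)c1` differs from compound 2 by chloro in place of bromo on an aromatic carbon. For the measured compounds named here, no measured pair shows this change, so no step beyond the usual scatter is expected in this assay, in either direction. Compound 3 is accordingly expected at 150000 nM, between 60000 nM and 400000 nM. The step this estimate means, a step that the limit leaves unreadable from compound 2 to compound 3, is expected to stay within the scatter and most likely to be reported only as a limit again.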

Compound 3, half-maximal cytotoxic concentration: > 100000 nM
Compound 3: no number, only a limit; the forecaster's own chance of this, stated with the estimate: 85%; the middle value is on the limit's open side.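

Compound 2 and compound 3 both give only a limit, so no step between them can be read: the limit of > 100000 nM in this assay, at which 3 of the 3 values shown sit.

The compounds shown leave open where any of them actually lies in this assay, and whether chloro and bromo differ there at all.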